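The source may hold more compounds than are shown below. What is called first, only, known or untested is meant among the compounds shown, and "the series" means these compounds.

In a functional assay on MDA-MB-231 cells (Homo sapiens) for cytotoxicity, read by MTT assay, with a stated time of 48 h (on this read-out lower numbers stand for stronger inhibition and higher numbers for weaker inhibition), compound 1 `O=C(/C=C/c1ccc2c(c1)B(O)OC2)c1ccc(-c2ccccc2)cc1` gives 6400 nM. Compound 2 `Cn1cccc1C(=O)/C=C/c1ccc2c(c1)B(O)OC2` stands at a limit of the assay, > 100000 nM, so only a bound and no number is known for it (the limit of > 100000 nM in this assay, at which 1 of the 2 values shown sits). Compound 3 `O=C(/C=C/c1ccc2c(c1)B(O)OC2)c1ccc(Cl)cc1` differs from compound 2 by 4-chlorophenyl in place of 1-methyl-1H-pyrrol-2-yl on a carbonyl carbon. Among the measured compounds shown here, no measured pair shows this step, so its size is not known. Because compound 1 gives 6400 nM, compound 3 is expected to move to stronger inhibition in this assay by a step of an at least 8.3-fold lower number from compound 2 to compound 3 (0.92 log units; beyond the scatter) that goes beyond the scatter. Compound 3 is therefore estimated at 12000 nM, with a range from 4000 nM to 50000 nM.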

Compound 3, half-maximal inhibitory concentration: 7900 nM
Estimate against measurement, compound 3: 1.5-fold (0.18 log units) above, and the stated range covers the measured number.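

In this assay, 4-chlorophenyl in place of 1-methyl-1H-pyrrol-2-yl on the carbonyl carbon gives an at least 12-fold lower number from compound 2 to compound 3 (1.10 log units; beyond the scatter), a step that is only a bound because compound 2 stands at a limit: the limit of > 100000 nM in this assay, at which 1 of the 3 values shown sits. Chloro in place of phenyl on the aromatic carbon gives a 1.2-fold higher number from compound 1 to compound 3 (0.09 log units; within the scatter), so phenyl and chloro at that place cannot be told apart in these two compounds. From the compounds shown here alone, what remains open is whether an amine or a carboxylic acid at that same place would give a similar value, and whether an unsubstituted phenyl on the carbonyl carbon would do so too.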